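This account rests on a few compounds, and the source may have more. Where it says the series, first, only, none or still open, it means among the compounds named here.

Compound 3 `Cc1nc2c(OCc3ccccc3)cccn2c1CO` holds the highest number of the three measured compounds in a functional assay on the whole organism (stomach) for inhibition, with Canis familiaris (Canis lupus familiaris) as the target, at a dose of 5 mg/kg by the intravenous route; on this read-out higher numbers stand for a stronger effect at the one dose given and lower numbers for a weaker effect: compound 3 gives 80%. Its two neighbours share the same core and differ only in the group on the aromatic carbon. Compound 1 `CC(=O)c1c(C)nc2c(OCc3ccccc3)cccn12` carries an acetyl there and gives 9% in this assay, and compound 2 `Cc1nc2c(OCc3ccccc3)cccn2c1C#N` carries a cyano and gives 4%. The step of a number 71 percentage points higher from compound 1 to compound 3 (beyond the scatter) and the step of a number 76 percentage points higher from compound 2 to compound 3 (beyond the scatter) are both large, while the step of a number 5 percentage points lower from compound 1 to compound 2 (within the scatter) is not.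

Compound 4 `Cc1nc2c(OCc3ccccc3)cccn2c1C[S+](C)[O-]` is the next compound; it differs from compound 3 by a group of 3 heavy atoms (1 carbon, 1 oxygen, 1 sulfur; no ring) in place of one oxygen atom, on a saturated chain carbon bound to an aromatic carbon. The two large steps show that this assay responds strongly to the group on that saturated chain carbon, and that the hydroxy of compound 3 went together with the high number. Since that hydroxy leaves in compound 4, a drop is expected, though of uncertain size. The expected step is a number 45 percentage points lower from compound 3 to compound 4 (beyond the scatter). For compound 4 the estimate is 35%, with a range from 8% to 70%.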

Compound 4, a percentage reported as inhibition, in the whole organism at one dose (the size of the read-out at that dose, not a potency): 18%
For compound 4 the middle estimate is 17 percentage points above the measured one; measured number inside the range.
By their numbers in this assay, from the lowest: compounds 2, 1 and 4 (each within the scatter of the next, the first and the last beyond it); then compound 3.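

In this assay the step of a number 62 percentage points lower from compound 3 to compound 4 (beyond the scatter) shows that the saturated chain carbon alone does not hold the high number: that carbon stays, only the hydroxy is replaced, and the entering group keeps 1 hydrogen-bond acceptor but has 0 donors. The new group also brings the compound down to the level of the earlier low compounds, with the step of a number 14 percentage points higher from compound 2 to compound 4 (beyond the scatter) and the step of a number 9 percentage points higher from compound 1 to compound 4 (within the scatter) placing it among them. No evidence is at hand on what lies behind this fall.

One sulfur-bearing group cannot show whether the loss of the hydroxy or the arrival of the larger group goes with the drop. A methoxy or an amine on the same saturated chain carbon, or a longer chain ending in a hydroxy, remains an open case.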